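One methoxy fewer: from compound 3 to compound 4

The source may report more compounds than this note shows. Statements on the series, on what has been measured and on what is new or still open speak of the compounds shown alone.

Measured in an ADME assay on HEK293 cells (Homo sapiens) for cytotoxicity, read by resazurin assay, with a stated time of 16 h; on this read-out higher numbers stand for an effect only at larger amounts of compound and lower numbers for an effect already at smaller amounts:
- compound 1 `C=CCOc1ccc(/C=C/C(=O)CC(=O)/C=C/c2ccc(OCC=C)c(OC)c2)cc1OC`: > 500000 nM (a limit, not a number)
- compound 2 `COc1cc(/C=C/C(=O)CC(=O)/C=C/c2ccc(OCC=C(C)C)cc2)ccc1OCC=C(C)C`: > 500000 nM (a limit, not a number)
- compound 3 `COc1cc(/C=C/C(=O)CC(=O)/C=C/c2ccc(OC(C)=O)c(OC)c2)ccc1OC(C)=O`: 80000 nM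

For the measured compounds named here, compound 3, at 80000 nM, holds the only true number in this small set. Compound 1 and compound 2 both sit at a limit: the limit of > 500000 nM in this assay, at which 2 of the 3 values shown sit. No gap to compound 3 can therefore be sized.

Compound 4 `COc1cc(/C=C/C(=O)CC(=O)/C=C/c2ccc(OC(C)=O)cc2)ccc1OC(C)=O` is still unmeasured. It has hydrogen in place of methoxy on an aromatic carbon, ortho to an acetoxy group, and the count of that change is hydrogen in place of methoxy on an aromatic carbon. Going by the values given here, no measured pair in the set shows what this exchange does on its own. The expectation in this assay is thus for no step beyond the usual scatter, in neither direction. Among the compounds with values here, that expectation leans on compound 3 at 80000 nM, the only measured compound that carries acetoxy groups, which compound 4 keeps. The expected move is a 1.1-fold higher number from compound 3 to compound 4 (0.05 log units; within the scatter). The estimate for compound 4 is 90000 nM, with an expected range from 35000 nM to 250000 nM.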

Compound 4, half-maximal effective concentration: 49000 nM
Beside the measured number, compound 4's estimate is 1.8-fold (0.26 log units) above it; the measured number falls inside the stated range.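

For the compounds shown here, this pair gives the first direct reading of the exchange, which the earlier compounds could not provide. In this assay, hydrogen in place of methoxy on an aromatic carbon, ortho to an acetoxy group, gives a 1.6-fold lower number from compound 3 to compound 4 (0.21 log units; within the scatter) and leaves the two compounds indistinguishable on this read-out. At this one position, with acetoxy groups kept on both sides of the molecule, the methoxy group can therefore be exchanged for hydrogen without a step beyond the usual scatter in this cytotoxicity measure, although a single pair cannot show whether the same holds elsewhere on the shared core.

The compounds shown leave open whether a different group at this position, such as a fluorine atom, an amine or a carboxylic acid, would give a step beyond the scatter, and whether a free hydroxyl group in place of the acetoxy group would alter the reading. Compound 1 and compound 2 each carry a limit rather than a number, so no steps involving them can be read: the limit of > 500000 nM in this assay, at which 2 of the 4 values shown sit.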